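Swapping the Aryl Group: Methyl Out, Bromine In

The source may hold more compounds than are shown below. What is called first, only, known or untested is meant among the compounds shown, and "the series" means these compounds.

Compound 1 `C/C(=C\CC/C(C)=C/CC[C@@H]1[C@@]2(C)CCC(=O)C(C)(C)[C@H]2CC[C@@]1(C)O)CC/C=C(\C)C(=O)OCc1cn(-c2cccc(O)c2)nn1` and compound 2 `C/C(=C\CC/C(C)=C/CC[C@@H]1[C@@]2(C)CCC(=O)C(C)(C)[C@H]2CC[C@@]1(C)O)CC/C=C(\C)C(=O)OCc1cn(-c2ccc(C)cc2)nn1` share a large core and differ only in the ring attached to an aromatic nitrogen. In an ADME assay on L132 cells (Homo sapiens) for cytotoxicity, read by MTT assay, with a stated time of 48 h (on this read-out higher numbers stand for weaker inhibition and lower numbers for stronger inhibition), compound 1 gives 146000 nM. Compound 2 in this assay reaches only the limit of > 150000 nM, so no exact number is known for it. The step of an at least 1.0-fold higher number from compound 1 to compound 2 (0.01 log units; that floor lies within the scatter) therefore cannot be sized beyond that floor, and the limit of > 150000 nM in this assay, at which 1 of the 2 values shown sits, shows where compound 2 sits. Compound 3 `C/C(=C\CC/C(C)=C/CC[C@@H]1[C@@]2(C)CCC(=O)C(C)(C)[C@H]2CC[C@@]1(C)O)CC/C=C(\C)C(=O)OCc1cn(-c2ccccc2Br)nn1` has not yet been measured in this assay. It differs from compound 2 in one place: 2-bromophenyl in place of 4-methylphenyl on an aromatic nitrogen. Among the measured compounds shown here, only one measured step bears on this kind of change, and it shows that going from 3-hydroxyphenyl to 4-methylphenyl left the value at the limit. With so little to go on, the expectation for compound 3 is a value close to the limit and no step beyond the scatter, expressed as a number no higher from compound 2 to compound 3 (the limit leaves the size open). Compound 3 is therefore estimated at 150000 nM, likely between 75000 nM and 300000 nM, with a fair chance that only a limit is reported again.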

Compound 3, half-maximal inhibitory concentration: > 150000 nM
Compound 3: only a limit was reported; the forecaster's own chance of this, stated with the estimate: 55%; the middle value sits exactly at the limit.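

Compound 3 gives only a limit in this assay, just as compound 2 does, so 2-bromophenyl on the aromatic nitrogen yields no exact number, any more than 4-methylphenyl did. Among the compounds shown here, the one step that can be read is an at least 1.0-fold higher number from compound 1 to compound 3 (0.01 log units; that floor lies within the scatter), so swapping 3-hydroxyphenyl for 2-bromophenyl shows no change that must exceed the scatter, though the real step could be larger. The step between the two limits cannot be read, which means 2-bromophenyl and 4-methylphenyl cannot be ranked against each other, and the new result adds only that the limit now holds for more of this small set: the limit of > 150000 nM in this assay, at which 2 of the 3 values shown sit.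

The compounds shown leave open how far the true values of compound 2 and compound 3 lie past their limits, and so whether either really differs from compound 1. Going by these compounds, it also remains open whether a phenyl ring carrying an amine or a carboxylic acid at this position would give a number clearly lower than those seen here.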